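This account rests on a few compounds, and the source may have more. Where it says the series, first, only, none or still open, it means among the compounds named here.

Measured so far in a functional assay on cells with prostaglandin E2 receptor EP2 subtype (Mus musculus) as the target; on this read-out higher numbers stand for an effect only at larger amounts of compound and lower numbers for an effect already at smaller amounts:

- compound 1, `CCCC1([C@@H](O)C/C=C/C2[C@H](O)CC(=O)[C@@H]2CCc2ccc(C(=O)O)cc2)CCC1`: 54 nM
- compound 2, `CCC1([C@@H](O)C/C=C/[C@H]2[C@H](O)CC(=O)[C@@H]2C/C=C\CCCC(=O)O)CCC1`: 11 nM
- compound 3, `CCCCCC1([C@@H](O)C/C=C/[C@H]2[C@H](O)CC(=O)[C@@H]2C/C=C\CCCC(=O)O)CCC1`: 130 nM

Compound 3 carries the highest number of the three; compound 1 with 54 nM sits nearer to it, compound 2 with 11 nM furthest away. Going by the values given here, the only single-point step among the measured compounds runs from compound 2 to compound 3: a 12-fold higher number from compound 2 to compound 3 (1.07 log units; beyond the scatter), where a longer chain on the cyclobutyl gave the larger number.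

Compound 4, `CC(C)CC1([C@@H](O)C/C=C/[C@H]2[C@H](O)CC(=O)[C@@H]2C/C=C\CCCC(=O)O)CCC1`, differs from compound 3 in one place: isopropyl in place of butyl on a saturated chain carbon bound to a saturated ring carbon. The chain on the cyclobutyl thus becomes shorter again, and branched, so compound 4 sits between compound 2 and compound 3 in chain length. Taking the step from compound 2 to compound 3 as the only guide, a move back toward the lower number is expected, though the branch leaves the size of the move uncertain; the expected step is a 3.3-fold lower number from compound 3 to compound 4 (0.51 log units; beyond the scatter). For compound 4 the estimate in this assay is 40 nM, with a range from 15 nM to 120 nM.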

Compound 4, half-maximal effective concentration: 45 nM
Compound 4: the middle estimate sits 1.1-fold (0.05 log units) below what was measured; measured number inside the range.
By their numbers in this assay, from the lowest: compound 2; then compounds 4 and 1 (each within the scatter of the next); then compound 3.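

In this assay the position on the cyclobutyl now shows a third level rather than a single jump. Replacing pentyl by isobutyl gives a 2.9-fold lower number from compound 3 to compound 4 (0.46 log units; beyond the scatter) but still leaves a 4.1-fold higher number from compound 2 to compound 4 (0.61 log units; beyond the scatter) on the other side. Across compound 2, compound 4 and compound 3 the number rises from the shortest group to the longest, and the branched group fits that order; no measurement on hand gives a reason for these steps.

Going by these compounds, whether the branch itself counts stays open, as isobutyl changes chain length and branching at once. A straight butyl chain on the cyclobutyl would separate the two, and a hydroxyl or an amine at the chain end would show how the number responds to anything other than carbon here.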